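The source may hold more compounds than are shown below. What is called first, only, known or untested is meant among the compounds shown, and "the series" means these compounds.

The study covers a set of compounds built on one shared core and read in a functional assay on the whole organism (strain Sprague-Dawley) for inhibition, with Rattus norvegicus as the target, read by paw edema, with a stated time of 4 h, at a dose of 70 mg/kg by the oral route; a higher number here means more inhibition at the dose given (going by the name of the read-out), a lower number less inhibition. Compound 1, `c1ccc(C2=NN(c3ccccc3)C3(S2)c2ccccc2Sc2ccccc23)cc1`, gives 85% in this assay. Compound 2, `CC(=O)C1=NN(c2ccccc2)C2(S1)c1ccccc1Sc1ccccc12`, gives 75%, and the step between them is a number 10 percentage points lower from compound 1 to compound 2 (within the scatter). Compound 3, `CC(=O)C1=NN(c2ccc(Cl)cc2)C2(S1)c1ccccc1Sc1ccccc12`, gives 82%; the step of a number 7 percentage points higher from compound 2 to compound 3 (within the scatter) places it second highest of the three numbers, yet it lies within the scatter of both compound 1 and compound 2, so no order among the three can be claimed.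

Compound 4 is `CC(=O)C1=NN(c2ccc([N+](=O)[O-])cc2)C2(S1)c1ccccc1Sc1ccccc12`. It differs from compound 3 in one place: nitro in place of chloro on an aromatic carbon. The measured step that bears most on this change is the one at the same aromatic carbon, a number 7 percentage points higher from compound 2 to compound 3 (within the scatter), which also exchanged the group on that carbon and stayed within the scatter. The other step, a number 10 percentage points lower from compound 1 to compound 2 (within the scatter), touched a different part of the core and was likewise within the scatter. Neither gives ground to expect a move in this assay beyond the scatter for compound 4, in either direction. The expected step is therefore a number 2 percentage points lower from compound 3 to compound 4 (within the scatter). Compound 4 is expected to give 80% in this assay, with a range from 68% to 90%.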

Compound 4, a percentage reported as inhibition, in the whole organism at one dose (the size of the read-out at that dose, not a potency): 86%
The estimate for compound 4 lay 6 percentage points below the measured number, within the range that was stated.
By their numbers in this assay, from the lowest: compounds 2, 3, 1 and 4 (each within the scatter of the next, the first and the last beyond it).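

In this assay, the change from 4-chlorophenyl to 4-nitrophenyl gives a number 4 percentage points higher from compound 3 to compound 4 (within the scatter), so at this aromatic carbon, para to a large group, the two groups cannot be told apart. Measured against hydrogen at the same carbon, however, nitro gives a number 11 percentage points higher from compound 2 to compound 4 (beyond the scatter), a modest step and the first in the series to lie beyond the scatter, whereas chloro gave a number 7 percentage points higher from compound 2 to compound 3 (within the scatter); the earlier compounds had not shown that a change at this position could register beyond the scatter at all. Nothing measured here accounts for this step.

On these data alone, whether an amine, a methoxy group or a carboxylic acid at this carbon would keep the number near that of compound 4 or bring it back towards that of compound 2 remains open, as does whether nitro would give a similar step on the phenyl-bearing core of compound 1. With a single dose and a single time point, the numbers also leave open how these compounds compare in potency or in the duration of their effect.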